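A cyano group added to compound 3

The compounds below may be only part of what the source reports. "The series", "measured", "known", "first", "only" and "open" are said of these compounds alone.

In an ADME assay on L02 cells (Homo sapiens) for cytotoxicity, read by MTT assay, with a stated time of 24 h (a higher number here means a weaker inhibitor, a lower number a stronger inhibitor), compound 1 (`CN1C/C(=C\c2cccnc2)C(=O)/C(=C/c2ccccc2C(F)(F)F)C1`) gives 14100 nM while compound 2 (`O=C1/C(=C/c2cccnc2)CN(S(=O)(=O)c2ccccc2)C/C1=C\c1ccccc1F`) gives 15300 nM and compound 3 (`O=C1/C(=C/c2ccncc2)CN(S(=O)(=O)c2ccccc2)C/C1=C\c1ccccc1F`) gives 15900 nM and so stands level with both, all three numbers lying within the scatter of one another. Compound 4 (`N#Cc1ccc(S(=O)(=O)N2C/C(=C\c3ccncc3)C(=O)/C(=C/c3ccccc3F)C2)cc1`) differs from compound 3 by a single change (cyano in place of hydrogen on an aromatic carbon) that turns phenylsulfonyl into (4-cyanophenyl)sulfonyl. Going by the values given here, no measured step touches this group. Among the compounds with values here, the only step available, pyridin-4-yl in place of pyridin-3-yl (a 1.0-fold higher number from compound 2 to compound 3 (0.02 log units; within the scatter)), concerns another part of the molecule and stays within the scatter. The expected step (a 1.1-fold lower number from compound 3 to compound 4 (0.03 log units; within the scatter)) is therefore none beyond the scatter, though the lack of direct evidence keeps the range wide. For compound 4 the estimate is 15000 nM with 8000 nM to 28000 nM as the expected range.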

Compound 4, half-maximal inhibitory concentration: > 20000 nM
Compound 4: only a limit was reported; the forecaster's own chance of this, stated with the estimate: 5%; at least 1.3-fold (0.12 log units) between middle value and limit.
By their numbers in this assay, from the lowest: compounds 1, 2 and 3 (each within the scatter of the next). At a limit, above all of these: compound 4.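

Going by these compounds alone, compound 4 is the only compound here with a group on the aromatic ring of the phenylsulfonyl part, and its value is a limit, not a number: the limit of > 20000 nM in this assay, at which 1 of the 4 values shown sits. Cyano in place of hydrogen at this position gives an at least 1.2-fold higher number from compound 3 to compound 4 (0.09 log units; that floor lies within the scatter). This change therefore gives no sign of a lower number, but whether the true gap lies beyond the scatter cannot be read.

On these data alone, whether an amine or a carboxylic acid on the same carbon would give a similar result remains open. So does the effect of cyano elsewhere on this ring.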